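From Compound 3 to Compound 4: One Added Chlorine

The compounds below may be only part of what the source reports. "The series", "measured", "known", "first", "only" and "open" are said of these compounds alone.

In a functional assay on CFPAC-1 cells (Homo sapiens) for antiproliferative activity, read by MTT assay, with a stated time of 72 h (on this read-out higher numbers stand for weaker inhibition and lower numbers for stronger inhibition), compound 1 `O=C1O[C@H]([C@@H](O)Cn2cc(-c3ccc(Br)cc3)nn2)C(OCc2ccccc2)=C1OCc1ccccc1`, which carries a 4-bromophenyl group, gives 5830 nM. Compound 2 `COc1ccccc1-c1cn(C[C@H](O)[C@H]2OC(=O)C(OCc3ccccc3)=C2OCc2ccccc2)nn1`, with a 2-methoxyphenyl group in that place, reads > 100000 nM, and this is a limit of the assay, not a number. Compound 3 `O=C1O[C@H]([C@@H](O)Cn2cc(CNS(=O)(=O)c3ccc(F)cc3)nn2)C(OCc2ccccc2)=C1OCc1ccccc1`, bearing an (((4-fluorophenyl)sulfonyl)amino)methyl group there, gives 34700 nM. That is the higher of the two actual numbers, and compound 1 holds the lower one.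

Compound 4 `O=C1O[C@H]([C@@H](O)Cn2cc(CNS(=O)(=O)c3ccc(Cl)cc3F)nn2)C(OCc2ccccc2)=C1OCc1ccccc1` departs from compound 3 in one place: 4-chloro-2-fluorophenyl in place of 4-fluorophenyl on a sulfonyl sulfur. It has 4-chloro-2-fluorophenyl in place of 4-fluorophenyl on a sulfonyl sulfur.

Among the compounds with values here, no measured step changes this group, so the evidence is indirect. The steps at hand exchange the whole substituent on an aromatic carbon: an at least 17-fold higher number from compound 1 to compound 2 (1.23 log units; beyond the scatter), a 6.0-fold higher number from compound 1 to compound 3 (0.77 log units; beyond the scatter) and an at least 2.8-fold lower number from compound 2 to compound 3 (0.45 log units; beyond the scatter). They show that the number in this assay can move widely among these three compounds, but they do not size a change this limited. The only weak hint comes from compound 1, whose phenyl group carries a bromine and which gives 5830 nM.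

A small lowering is therefore expected, not clearly beyond the scatter, and the estimated step is a 1.6-fold lower number from compound 3 to compound 4 (0.20 log units; within the scatter). Compound 4 is expected to give about 22000 nM, with an estimated range from 8000 nM to 60000 nM.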

Compound 4, half-maximal inhibitory concentration: 58200 nM
The estimate for compound 4 lay 2.6-fold (0.42 log units) below the measured number; low and high end bracket the measured number.
By their numbers in this assay, from the lowest: compound 1; then compounds 3 and 4 (each within the scatter of the next). At a limit, above all of these: compound 2.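

In this assay, within the data shown here, the position on the sulfonyl sulfur now has a direct reading for the first time: 4-chloro-2-fluorophenyl in place of 4-fluorophenyl gives a 1.7-fold higher number from compound 3 to compound 4 (0.22 log units; within the scatter). This exchange within the sulfonyl substituent therefore does not separate the two compounds, whereas the exchange of the whole substituent on the aromatic carbon, a 6.0-fold higher number from compound 1 to compound 3 (0.77 log units; beyond the scatter), does lie beyond the scatter. Nothing at hand offers a cause for the reading at this position.

The compounds shown leave open whether a group of another kind on the sulfonyl sulfur, such as a plain methyl or a phenyl carrying an amine or a carboxylic acid, would move the number beyond the scatter. They also leave open how the chlorine and the added fluorine of the 4-chloro-2-fluorophenyl group would each read alone, as a 4-chlorophenyl or a 2-fluorophenyl group on the same sulfonyl sulfur would show.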